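Swapping a fluorophenyl for a furan on a shared core

This account rests on a few compounds, and the source may have more. Where it says the series, first, only, none or still open, it means among the compounds named here.

Two compounds share a core and differ only in the aromatic group attached to it. Compound 1 `CC(C)(C)n1ncc(OCc2nnc(-c3c(F)cccc3F)o2)c(Cl)c1=O` gives 45.4 ug/mL in a functional assay on the whole organism for inhibition, with Mythimna separata as the target, with a stated time of 5 days (a lower number here means that less compound is needed, a higher number that more compound is needed for the effect), while compound 2 `CC(C)(C)n1ncc(OCc2nnc(-c3ccc(F)cc3)o2)c(Cl)c1=O` gives 5.2 ug/mL. Within the data shown here, the single measured step is an 8.7-fold lower number from compound 1 to compound 2 (0.94 log units; beyond the scatter), so compound 2 holds the lower of the two numbers. Compound 3 `CC(C)(C)n1ncc(OCc2nnc(-c3ccco3)o2)c(Cl)c1=O` takes the next step from compound 2: furan-2-yl in place of 4-fluorophenyl on an aromatic carbon. Among the measured compounds shown here, the only measured step exchanged one fluorinated benzene ring for another, so it speaks to the change here only loosely; nothing measured shows what a five-membered ring with an oxygen does at this place. Given that gap, the step is expected to be small, with the number likely drifting somewhat higher, as a 1.9-fold higher number from compound 2 to compound 3 (0.28 log units; within the scatter). Compound 3 is therefore estimated at 10 ug/mL, with a range from 3 ug/mL to 40 ug/mL.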

Compound 3, half-maximal effective concentration: > 300 ug/mL
Compound 3 was reported as a limit; the forecaster's own chance of this, stated with the estimate: 5%; at least 30-fold (1.47 log units) between middle value and limit.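

In this assay compound 3 gives a limit and not a number: the limit of > 300 ug/mL in this assay, at which 1 of the 3 values shown sits. The steps can still be read as minimum sizes: furan-2-yl in place of 4-fluorophenyl gives an at least 57-fold higher number from compound 2 to compound 3 (1.76 log units; beyond the scatter), and furan-2-yl in place of 2,6-difluorophenyl gives an at least 6.6-fold higher number from compound 1 to compound 3 (0.82 log units; beyond the scatter). This position on the five-membered ring is therefore sensitive to more than the fluorine pattern on a benzene ring, and the change to furan-2-yl gives the largest step among these compounds, taking the read-out out of the range that yields a number at all.

The compounds shown leave open whether this loss goes with the ring oxygen, the smaller ring or the absence of fluorine. An unsubstituted phenyl or a thiophen-2-yl at this place would help to tell these apart.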